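The source may report more compounds than this note shows. Statements on the series, on what has been measured and on what is new or still open speak of the compounds shown alone.

Three compounds sharing one core, and differing only in the substituted phenyl group, have been measured so far. In a physicochemical assay for solubility, in phosphate buffer, measured as kinetic solubility, at pH 7.4 (a lower number here means a less soluble compound, a higher number a more soluble compound), compound 1 `COc1cccc(Br)c1-c1nc(CN2CCC(C(=O)NCCCN3C[C@H](C)C[C@H](C)C3)CC2)c(C)o1` reads > 83 ug/mL, which is a limit of the assay and not a number. Compound 2 `Cc1cccc(C)c1-c1nc(CN2CCC(C(=O)NCCCN3C[C@H](C)C[C@H](C)C3)CC2)c(C)o1` gives 55.9 ug/mL, the only one of the three reported as a number. Compound 3 `Cc1ccc(-c2nc(CN3CCC(C(=O)NCCCN4C[C@H](C)C[C@H](C)C4)CC3)c(C)o2)c(C)c1` reads > 71 ug/mL, which is likewise only a limit.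

The next compound, compound 4 `COc1ccc(-c2nc(CN3CCC(C(=O)NCCCN4C[C@H](C)C[C@H](C)C4)CC3)c(C)o2)cc1OC`, has 3,4-dimethoxyphenyl in place of 2,4-dimethylphenyl on an aromatic carbon. Among the compounds with values here, no measured step makes exactly this exchange, but three steps change the same phenyl group. The data show an at least 1.2-fold higher number from compound 2 to compound 3 (0.10 log units; that floor lies within the scatter) and an at least 1.4-fold lower number from compound 1 to compound 2 (0.17 log units; that floor lies within the scatter), and both of these floors lie within the scatter. The third is a step that the two limits leave unreadable from compound 1 to compound 3, whose size cannot be read. None of the three therefore shows a change beyond the scatter in this assay, so no clear shift in either direction is expected here. The expected change is a step that the limit leaves unreadable from compound 3 to compound 4, and it is estimated to stay within the scatter. For compound 4 the estimated value is 72 ug/mL, with an expected range from 45 ug/mL to 100 ug/mL.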

Compound 4, solubility: > 76 ug/mL
Compound 4 ended at the assay's limit; the forecaster's own chance of this, stated with the estimate: 60%; at least 1.0-fold (0.02 log units) between middle value and limit.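

In this assay, compound 4 gives a limit of the assay and not a number: the limit of > 76 ug/mL in this assay, at which 1 of the 4 values shown sits. The exchange of 2,4-dimethylphenyl for 3,4-dimethoxyphenyl brings in oxygen and hydrogen-bond acceptors at this position, yet the reading stays at a limit, so three different phenyl groups now give limits, and compound 2 alone has a number. Within the data shown here, the steps to compound 4 from compound 3 and from compound 1 cannot be read, and the one readable step, an at least 1.3-fold higher number from compound 2 to compound 4 (0.13 log units; that floor lies within the scatter), therefore gives no change beyond the scatter for this group.

The true values of compound 1, compound 3 and compound 4 remain unknown, so the compounds shown give no order among these three and cannot tell whether any of the exchanges at this position changes the reading at all. Also open, going by these compounds, is how the reading would respond to a phenyl group carrying an amine or a carboxylic acid, or to a pyridine ring in place of the phenyl ring.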